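A few compounds are considered here, and "the series" means these few. Any claim that something is new, unique, unknown or untested is made for them only; others in the source may bear on it.

Measured in an assay on BaF3 cells for inhibition of proto-oncogene tyrosine-protein kinase receptor Ret variant V804M (Homo sapiens), read by MTT assay, with a stated time of 48 h; on this read-out lower numbers stand for stronger inhibition of growth and higher numbers for weaker inhibition of growth:
Compound 1 `CC(C)n1nc(-c2ccon2)c2c(N)ncnc21` gives 8940 nM.
Compound 2 `CC(C)(O)Cn1nc(-c2cc(C3CC3)on2)c2c(N)ncnc21` gives 6750 nM.
Compound 3 `CC(C)n1nc(/C=N/O)c2c(N)ncnc21` reaches only the limit of this assay, > 10000 nM (the limit of > 10000 nM in this assay, at which 1 of the 3 values shown sits).

Compound 2 and compound 1 sit within the scatter of one another, and compound 3 stands at a limit rather than a number. Compound 4 `Cn1nc(-c2cc(C3CC3)on2)c2c(N)ncnc21` differs from compound 2 by hydrogen in place of 1-hydroxy-1-methylethyl on a saturated chain carbon bound to an aromatic nitrogen. For the measured compounds named here, the only measured step, an at least 1.1-fold higher number from compound 1 to compound 3 (0.04 log units; that floor lies within the scatter), alters a different part of the shared core and does not bear on this change. Nothing measured therefore points to a step beyond the scatter in this assay, and the estimated step of a 1.2-fold higher number from compound 2 to compound 4 (0.07 log units; within the scatter) is taken as small. Compound 4 is expected to give about 8000 nM, between 2500 nM and 25000 nM.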

Compound 4, concentration for 50% growth inhibition: 5560 nM
The estimate for compound 4 lay 1.4-fold (0.16 log units) above the measured number, and the stated range covers the measured number.
By their numbers in this assay, from the lowest: compounds 4, 2 and 1 (each within the scatter of the next). At a limit, above all of these: compound 3.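

Putting hydrogen in place of 1-hydroxy-1-methylethyl on a saturated chain carbon bound to an aromatic nitrogen gives a 1.2-fold lower number from compound 2 to compound 4 (0.08 log units; within the scatter) in this assay. For the compounds shown here, this is the first measured step at this position, and it shows that 2-hydroxy-2-methylpropyl can be cut back to methyl with no change beyond the scatter. The data shown offer no explanation of this result.

Going by these compounds, whether an amine, a carboxylic acid or a longer chain at this position would move the number beyond the scatter remains open.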